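The compounds below may be only part of what the source reports. "The series", "measured", "known", "first", "only" and "open" are said of these compounds alone.

Working notes on the series. The shared core is that of compound 1 `CCCC(=O)NCCC(=O)c1cc(OC)ccc1N`; in a functional assay for inhibition of kynurenine 3-monooxygenase (Rattus norvegicus), tested at 1 mM (on this read-out lower numbers stand for less inhibition and higher numbers for more inhibition at the one concentration tested (going by the name of the read-out)), compound 1 has "not determined" (no result reported). Compound 2 `COc1ccc(N)c(C(=O)CCNC(=O)C2CCCCC2)c1` gives 99.6%, and compound 3 `COc1ccc(N)c(C(=O)CCNC(C)=O)c1` gives 102%, which puts compound 3 alongside compound 2 with nothing between them beyond the scatter: the step of a number 2.4 percentage points higher from compound 2 to compound 3 (within the scatter) is flat. Compound 4 `COc1ccc(N)c(C(=O)CCNC(=O)C2CCCC2)c1` differs from compound 3 by cyclopentyl in place of methyl on a carbonyl carbon. Among the measured compounds shown here, the only step that bears on this is the one from compound 2 to compound 3, where cyclohexyl against methyl on the same carbonyl carbon changed nothing beyond the scatter; cyclopentyl is expected to behave likewise, so the expected step of a number 2 percentage points lower from compound 3 to compound 4 (within the scatter) is none beyond the scatter. Compound 4 is therefore estimated at 100%, within 92% to 105%.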

Compound 4, a percentage reported as inhibition, at one concentration (the size of the read-out at that concentration, not a potency): 96.3%
Compound 4: middle estimate off by 3.7 percentage points, on the high side; the measured number falls inside the stated range.
By their numbers in this assay, from the lowest: compounds 4, 2 and 3 (each within the scatter of the next).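

Cyclopentyl in place of methyl on a carbonyl carbon gives a number 5.7 percentage points lower from compound 3 to compound 4 (within the scatter) in this assay, and cyclopentyl in place of cyclohexyl gives a number 3.3 percentage points lower from compound 2 to compound 4 (within the scatter). A five-membered ring of carbon thus joins methyl and cyclohexyl as a third group at this position with no separation among them. No supporting evidence bears on this result.

A single tested concentration cannot rank these compounds. As far as these compounds go, whether a carboxylic acid, an amine or a longer chain on this carbonyl carbon would also leave the read-out unchanged remains open.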